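Methyl to fluoro on the core of compound 1: cytotoxicity notes

The source may hold more compounds than are shown below. What is called first, only, known or untested is meant among the compounds shown, and "the series" means these compounds.

Compound 1 `COc1ccc(Oc2ccc(N3CC(=O)N([C@@H](CC4CCN(C(=O)C(C)C)CC4)c4nc5ccc(C)cc5n4C)C3=O)cc2)cc1` is the reference point for this step. In an ADME assay on Huh-7 cells (Homo sapiens) for cytotoxicity, read by MTT assay (on this read-out lower numbers stand for stronger inhibition and higher numbers for weaker inhibition), compound 1 gives only a limit, > 100000 nM, and not a number. Compound 2 `CC(C)C(=O)N1CCC(C[C@@H](c2nc3ccc(F)cc3n2C2CC2)N2C(=O)CN(c3ccc(Oc4ccc(F)cc4)cc3)C2=O)CC1` likewise returns a limit in this assay, > 100000 nM. Compound 3 `COc1ccc(Oc2ccc(N3CC(=O)N([C@@H](CC4CCN(C(=O)C(C)C)CC4)c4nc5ccc(C)cc5n4C4CC4)C3=O)cc2)cc1` also sits at a limit in this assay, > 100000 nM. Going by the values given here, the one measured step that can be framed, a step that the two limits leave unreadable from compound 1 to compound 3, stays unreadable since both ends are limits, so no measured step of known size bears on the change now under review.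

Compound 4 `COc1ccc(Oc2ccc(N3CC(=O)N([C@@H](CC4CCN(C(=O)C(C)C)CC4)c4nc5ccc(F)cc5n4C)C3=O)cc2)cc1` differs from compound 1 by fluoro in place of methyl on an aromatic carbon. Every measured value in this assay sits at the same limit, (the limit of > 100000 nM in this assay, at which 3 of the 3 values shown sit), so the series gives no sign that any single change at the core shifts cytotoxicity out of the unreadable range. The expectation for compound 4 is therefore no readable step in this assay, a step that the limit leaves unreadable from compound 1 to compound 4, with the result again most likely a limit. Compound 4 is estimated at 150000 nM, with a range of 80000 nM to 300000 nM.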

Compound 4, half-maximal inhibitory concentration: > 100000 nM
Compound 4 ended at the assay's limit; the forecaster's own chance of this, stated with the estimate: 90%; the middle value does not contradict the limit.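

Compound 4, like compound 1, stands at a limit in this assay, so the swap of methyl for fluoro gives no readable step: the limit of > 100000 nM in this assay, at which 4 of the 4 values shown sit.

The compounds shown leave open what size, if any, a change on the shared core has in this assay.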